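The source may report more compounds than this note shows. Statements on the series, on what has been measured and on what is new or still open speak of the compounds shown alone.

Working notes on the series.

The shared core of compound 3 `CCCCCCC(=O)OCc1ccc2oc(=O)c(C(=O)Oc3cccc(Br)c3)cc2c1` carries a hexylcarbonyl ester on the methyl arm. In a functional assay on HT-1080 cells (Homo sapiens), read by transwell migration, with a stated time of 24 h, tested at 0.1 uM (on this read-out higher numbers stand for a weaker effect at the one concentration tested and lower numbers for a stronger effect), compound 3 gives 89.4%, the highest of the three numbers shown. Its nearest neighbour is compound 2 `CCC(=O)OCc1ccc2oc(=O)c(C(=O)Oc3cccc(Br)c3)cc2c1`, which in this assay gives 84.4%; the step of a number 5 percentage points higher from compound 2 to compound 3 (within the scatter) lies within the scatter. Furthest away is compound 1 `CC(=O)OCc1ccc2oc(=O)c(C(=O)Oc3cccc(Br)c3)cc2c1`, which gives 39.5%; the step of a number 49.9 percentage points higher from compound 1 to compound 3 (beyond the scatter) is large, as is a number 44.9 percentage points higher from compound 1 to compound 2 (beyond the scatter).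

Compound 4 `CC(C)(C)C(=O)OCc1ccc2oc(=O)c(C(=O)Oc3cccc(Br)c3)cc2c1` is the next member: tert-butyl in place of hexyl on a carbonyl carbon. The acyl group stays larger than the acetyl of compound 1, so the large steps of a number 44.9 percentage points higher from compound 1 to compound 2 (beyond the scatter) and a number 49.9 percentage points higher from compound 1 to compound 3 (beyond the scatter) mark the jump that compound 4 has already made, while a number 5 percentage points higher from compound 2 to compound 3 (within the scatter) shows that further growth of the chain beyond compound 2 changed nothing beyond the scatter. Among the compounds with values here, no measured step tests branching at the carbon bound to the carbonyl, so that part of the change is untested. The expectation is therefore a step of a number 5.4 percentage points lower from compound 3 to compound 4 (within the scatter) that stays within the scatter. Compound 4 is estimated at 84% in this assay, with a range from 64% to 98%.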

Compound 4, a percentage reported as activity, at one concentration (the size of the read-out at that concentration, not a potency): 65.2%
Estimate against measurement, compound 4: 18.8 percentage points above; the measured number falls inside the stated range.
By their numbers in this assay, from the lowest: compound 1; then compound 4; then compounds 2 and 3 (each within the scatter of the next).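

In this assay, tert-butyl on a carbonyl carbon does not fall in with the straight chains, giving a number 24.2 percentage points lower from compound 3 to compound 4 (beyond the scatter) and a number 19.2 percentage points lower from compound 2 to compound 4 (beyond the scatter), while still standing apart from the methyl of the acetyl ester, with a number 25.7 percentage points higher from compound 1 to compound 4 (beyond the scatter). This position therefore does not divide simply into acetyl and every larger acyl group: compounds 2 and 3 stay within the scatter of each other, whereas compound 4 goes against that grouping and occupies a middle place of its own, with only four carbons in the entering group against six in the hexyl it replaces. Nothing among the data offered here accounts for this middle place.

The compounds shown leave open whether the shape of tert-butyl or its carbon count sets this middle value, and isopropyl or cyclopropyl on the same carbonyl carbon would bear directly on that question. They also leave open whether a phenyl group, a chain ending in an amine, or a chain ending in a carboxylic acid would stay close to compound 1 or to compounds 2 and 3 at this single concentration.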